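Ether chain variation on the aminodicyanopyridine thioether series

The source may report more compounds than this note shows. Statements on the series, on what has been measured and on what is new or still open speak of the compounds shown alone.

Measured so far:
compound 1 `N#Cc1c(N)nc(SCc2ccn[nH]2)c(C#N)c1-c1ccc(OCC2CC2)cc1` with 552 nM
compound 2 `C=CCOc1ccc(-c2c(C#N)c(N)nc(SCC(N)=O)c2C#N)cc1` with 323 nM
compound 3 `N#Cc1c(N)nc(SCc2cccc(C(N)=O)c2)c(C#N)c1-c1ccc(OCC2CC2)cc1` with 83 nM

In an assay on CHO cells for displacement of a labelled ligand from adenosine receptor A1 (Homo sapiens), read by scintillation counting, with a stated time of 90 min (on this read-out lower numbers stand for stronger inhibition and higher numbers for weaker inhibition), compound 2 gives 323 nM, the second highest of the three numbers. Its nearest neighbour is compound 1, which in this assay gives 552 nM, a gap within the scatter; the furthest is compound 3 at 83 nM, which lies beyond the scatter. Among the compounds with values here, the one single-point step measured so far, a 6.7-fold lower number from compound 1 to compound 3 (0.82 log units; beyond the scatter), concerns the group on the saturated chain carbon bound to the sulfur, not the ether chain.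

Compound 4 `CC(C)COc1ccc(-c2c(C#N)c(N)nc(SCC(N)=O)c2C#N)cc1` differs from compound 2 only at the ether side: isopropyl in place of vinyl on a saturated chain carbon bound to an oxygen on an aromatic ring. Within the data shown here, no measured step touches this position, since compounds 1 and 3 differ from compound 2 at the sulfur side as well. Without a comparison at the ether chain, the expectation is that a 1.1-fold lower number from compound 2 to compound 4 (0.03 log units; within the scatter) stays within the scatter. Compound 4 is therefore estimated at 300 nM in this assay, with a range from 110 nM to 800 nM.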

Compound 4, inhibition constant: 603 nM
Beside the measured number, compound 4's estimate is 2.0-fold (0.30 log units) below it; the measured number falls inside the stated range.
By their numbers in this assay, from the lowest: compound 3; then compounds 2, 1 and 4 (each within the scatter of the next).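

In this assay, within the data shown here, the exchange at the ether side gives the first direct comparison at this position: a 1.9-fold higher number from compound 2 to compound 4 (0.27 log units; within the scatter). With the sulfur side held constant, allyloxy and isobutoxy cannot be told apart in this pair, so neither the double bond outside aromatic rings nor the larger isobutyl group shows a measurable consequence here. No supporting evidence bears on this result.

The compounds shown leave open whether this tolerance holds with the 3-carbamoylphenyl group on the sulfur side, since compounds 1 and 3 differ from compound 4 in more than one place. They also leave open how a longer straight chain, or a chain ending in an amine or a carboxylic acid, would read on this position.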